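Chloro for isopropyl in a series at the assay limit

The source may report more compounds than this note shows. Statements on the series, on what has been measured and on what is new or still open speak of the compounds shown alone.

Of the compounds shown here, three have been measured so far in a functional assay on MCF7 cells (Homo sapiens) for antiproliferative activity, read by MTT assay, with a stated time of 72 h; a higher number here means a weaker inhibitor, a lower number a stronger inhibitor. Compound 1 `CC(C)c1ccc(NCC(=O)N[C@H]2CCOC2=O)cc1` is reported only as a limit: in this assay compound 1 gives > 64000 nM. Compound 2 `O=C1OCC[C@@H]1NC(=S)SCCOc1ccc([N+](=O)[O-])cc1` likewise sits at a limit, and in this assay compound 2 gives > 64000 nM. Compound 3 `CC(=O)c1ccc(OCCSC(=S)N[C@H]2CCOC2=O)cc1` is a limit too; in this assay compound 3 gives > 64000 nM. Going by the values given here, the one single-point step among them, a step that the two limits leave unreadable from compound 2 to compound 3, is therefore unreadable, and all the series offers is the limit of > 64000 nM in this assay, at which 3 of the 3 values shown sit.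

Compound 4 `O=C(CNc1ccc(Cl)cc1)N[C@H]1CCOC1=O` is not yet measured. It differs from compound 1 by chloro in place of isopropyl on an aromatic carbon. Among the compounds with values here, no measured step bears on this change; the one step known concerns a different change and its size cannot be read. With compound 1 standing at the limit, nothing in the data places compound 4 away from it, so the expected step that the limit leaves unreadable from compound 1 to compound 4 is none beyond the scatter, with a high chance that compound 4 is again reported only as a limit. The estimate for compound 4 in this assay is 90000 nM, expected within 30000 nM to 250000 nM.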

Compound 4, half-maximal inhibitory concentration: > 64000 nM
Compound 4: only a limit was reported; the forecaster's own chance of this, stated with the estimate: 85%; the middle value does not contradict the limit.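

Compound 1 and compound 4 are both reported only as limits in this assay, so no step can be read for chloro in place of isopropyl. The compounds shown leave open whether any change to the shared core gives a readable value: the limit of > 64000 nM in this assay, at which 4 of the 4 values shown sit.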